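From tert-butyl to chloro on the aromatic ring

The compounds below may be only part of what the source reports. "The series", "measured", "known", "first", "only" and "open" are said of these compounds alone.

- Compound 1 `CC(C)(C)c1ccc(OCCCON2C(N)=NC(N)=NC23CCSCC3)cc1` gives 70 nM
- Compound 2 `NC1=NC2(CCOCC2)N(OCCCOc2cccc(Cl)c2Cl)C(N)=N1` gives 330 nM
- Compound 3 `NC1=NC2(CCOCC2)N(OCCCOc2ccc(F)cc2)C(N)=N1` gives "not determined" (no result reported)
- Compound 4 `NC1=NC2(CCSCC2)N(OCCCOc2ccc(Cl)cc2)C(N)=N1` is still unmeasured

In a functional assay on HepG2 cells (Homo sapiens) for antiproliferative activity, read by MTT assay, with a stated time of 72 h (a lower number here means a stronger inhibitor, a higher number a weaker inhibitor), compound 1 holds the lower of the two numbers, and the gap up to compound 2 lies beyond the scatter. Compound 3 has no number. Compound 4 differs from compound 1 by chloro in place of tert-butyl on an aromatic carbon with chloro in place of tert-butyl on an aromatic carbon, para to a large group. Within the data shown here, no measured pair isolates this change. Compound 2 differs from compound 1 in more than one place, but it also bears chloro on its aromatic ring. In this assay compound 2 gives 330 nM as its result. The expected step is a 2.9-fold higher number from compound 1 to compound 4 (0.46 log units; beyond the scatter) toward a weaker inhibitor. For compound 4 the estimated value is 200 nM with an expected range from 60 nM to 700 nM in this measurement.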

Compound 4, half-maximal inhibitory concentration: 1100 nM
The estimate for compound 4 lay 5.5-fold (0.74 log units) below the measured number; measured number outside the range, above it.
By their numbers in this assay, from the lowest: compound 1; then compound 2; then compound 4.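

In this assay, among these compounds, chloro in place of tert-butyl on an aromatic carbon, para to a large group, brings a 16-fold higher number from compound 1 to compound 4 (1.20 log units; beyond the scatter) and so gives the first matched reading of this change. With the rest of compound 1 held fixed, this position is clearly not indifferent to the group it carries, and tert-butyl gives the stronger inhibitor of the pair. Nothing measured here accounts for the size of this step.

The compounds shown leave open how an isopropyl group, a methoxy group or an amine would read at this position. A single pair also establishes no trend across groups.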